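The compounds below may be only part of what the source reports. "The series", "measured", "known", "first", "only" and "open" are said of these compounds alone.

In an ADME assay on microsomes from liver (Homo sapiens) for metabolic stability, with a stated time of 10 min, tested at 0.5 uM (a higher number here means that more of the compound is left, a lower number that less of the compound is left), compound 1 `CCc1noc(C)c1[C@@H]1C[C@@](C)(c2ccc(F)cc2F)N=C(N)S1` gives 21%. Compound 3 `Cc1onc(-c2ccc(F)cc2)c1[C@@H]1C[C@@](C)(c2ccc(F)cc2F)N=C(N)S1` gives 24%, and a number 3 percentage points higher from compound 1 to compound 3 (within the scatter) leaves these two level. Compound 2 `Cc1onc(-c2ccccc2)c1[C@@H]1C[C@@](C)(c2ccc(F)cc2F)N=C(N)S1` gives 38%, the highest of the three, with a number 17 percentage points higher from compound 1 to compound 2 (beyond the scatter) and a number 14 percentage points lower from compound 2 to compound 3 (beyond the scatter).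

Compound 4 `Cc1nocc1[C@@H]1C[C@@](C)(c2ccc(F)cc2F)N=C(N)S1` is still unmeasured. It differs from compound 1 as follows: 3-methyl-1,2-oxazol-4-yl in place of 3-ethyl-5-methyl-1,2-oxazol-4-yl on a saturated ring carbon. In words, 3-methyl-1,2-oxazol-4-yl stands in place of 3-ethyl-5-methyl-1,2-oxazol-4-yl on a saturated ring carbon, next to the ring sulfur.

The measured steps from compound 1 only replace the ethyl group with phenyl or 4-fluorophenyl. None of them removes a group, so they are a loose guide to size and a weak one to direction. Neither replacement brought a drop, and the larger of the two was a number 17 percentage points higher from compound 1 to compound 2 (beyond the scatter). A small upward step is therefore expected, estimated as a number 9 percentage points higher from compound 1 to compound 4 (within the scatter). For compound 4 the estimated value is 30%, with an expected range of 12% to 50%.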

Compound 4, percent of the compound remaining: 65%
Estimate against measurement, compound 4: 35 percentage points below; measured number outside the range, above it.
By their numbers in this assay, from the lowest: compounds 1 and 3 (each within the scatter of the next); then compound 2; then compound 4.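

In this assay, going from the 8 heavy atoms of 3-ethyl-5-methyl-1,2-oxazol-4-yl to the 6 of 3-methyl-1,2-oxazol-4-yl gives a number 44 percentage points higher from compound 1 to compound 4 (beyond the scatter). The earlier steps shown here only exchanged the ethyl group for phenyl or 4-fluorophenyl, and this trimming of the group on the saturated ring carbon moves the number far more than either exchange did, so this position can shift the read-out strongly. No measurement shown here explains the rise.

This single change shortens ethyl to methyl and also drops the 5-methyl group, and the compounds shown do not separate the two; 3-ethyl-1,2-oxazol-4-yl or 3,5-dimethyl-1,2-oxazol-4-yl would each carry only one of them. On these data alone, it also remains open how the bare 1,2-oxazol-4-yl group would compare.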